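Bromo-to-trifluoromethyl swap on the aryl group of compound 1

This account rests on a few compounds, and the source may have more. Where it says the series, first, only, none or still open, it means among the compounds named here.

Measured so far:
- compound 1 `COc1ccc2cc(C(C)c3nnc4n3N=C(c3ccc(Br)cc3)CS4)ccc2c1`: 11500 nM
- compound 2 `CC(c1ccc(-c2ccccc2)c(F)c1)c1n[nH]c(=S)n1N`: "not active" (no number reported)
- compound 3 `CC(c1ccc(-c2ccccc2)c(F)c1)c1nnc2n1N=C(c1ccc(Cl)cc1)CS2`: 8700 nM

In a functional assay on MCF7 cells (Homo sapiens) for inhibition, read by sulforhodamine B assay, with a stated time of 72 h (a higher number here means a weaker inhibitor, a lower number a stronger inhibitor), compound 1 gives 11500 nM. Of the two compounds with a reported number it carries the higher one, yet its nearest neighbour, compound 3 with 8700 nM, lies within the scatter of it, so no order between the two can be read. Compound 2 is reported as "not active" (no number reported) in this assay, without a number; it has the open core rather than the fused one of compounds 1 and 3.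

Compound 4 `COc1ccc2cc(C(C)c3nnc4n3N=C(c3ccc(C(F)(F)F)cc3)CS4)ccc2c1` is not yet measured. It differs from compound 1 in one place: trifluoromethyl in place of bromo on an aromatic carbon, para to a large group. For the measured compounds named here, no measured pair shows this exact change, so there is no step to draw on; the comparison between compound 1 and compound 3, which differ in several places at once, only shows two values close together.

On that basis compound 4 is expected near compound 1, with the change from compound 1 to compound 4 in this assay estimated as a 1.2-fold lower number from compound 1 to compound 4 (0.06 log units; within the scatter), not beyond the scatter in either direction. The estimate for compound 4 is 10000 nM, with a range from 4000 nM to 30000 nM.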

Compound 4, half-maximal inhibitory concentration: 6900 nM
Compound 4: the middle estimate sits 1.4-fold (0.16 log units) above what was measured, within the range that was stated.
By their numbers in this assay, from the lowest: compounds 4, 3 and 1 (each within the scatter of the next).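

In this assay the series now has its first comparison of two compounds that differ in one place, and this step reads as a 1.7-fold lower number from compound 1 to compound 4 (0.22 log units; within the scatter) for trifluoromethyl in place of bromo on an aromatic carbon, para to a large group. Compounds 1 and 3 differ in several places at once and could not isolate this position, whereas here the change from 4-bromophenyl to 4-(trifluoromethyl)phenyl, from 1 heavy atom to 4 heavy atoms, leaves the two values within the scatter of each other and gives no order between the two groups. Nothing measured for these compounds accounts for this result or links it to any property of either group.

From the compounds shown here alone, whether an amine, a carboxylic acid or a nitrile at this same place would give a value beyond the scatter of compound 1 remains open. Also open, going by these compounds, is whether the same swap would read alike on the other side of the shared core, in the setting of compound 3, which carries a chloro group at this place.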